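Swapping naphthalen-2-yl for 3-fluorophenyl in a small series

The source may report more compounds than this note shows. Statements on the series, on what has been measured and on what is new or still open speak of the compounds shown alone.

Compound 1 `Cc1cc(Nc2ccc(C(=O)/C=C/c3ccc(OC(F)(F)F)cc3)cc2)n2nc(SCc3nc4ccccc4[nH]3)nc2n1` gives 220 nM
Compound 2 `Cc1cc(Nc2ccc(C(=O)/C=C/c3ccc4ccccc4c3)cc2)n2nc(SCc3nc4ccccc4[nH]3)nc2n1` gives 5 nM

Both numbers come from a functional assay on SW-620 cells (Homo sapiens) for cytotoxicity, read by MTT assay, with stated times of 4 h and 72 h, tested at 2 uM (a higher number here means a weaker inhibitor, a lower number a stronger inhibitor), and compound 2 stands lowest of the two at 5 nM as the stronger inhibitor so far. The next compound to be measured is compound 3 `Cc1cc(Nc2ccc(C(=O)/C=C/c3cccc(F)c3)cc2)n2nc(SCc3nc4ccccc4[nH]3)nc2n1` with 3-fluorophenyl in place of naphthalen-2-yl on a double-bonded chain carbon bound to a double-bonded chain carbon. The change counts as follows: 3-fluorophenyl in place of naphthalen-2-yl on a double-bonded chain carbon bound to a double-bonded chain carbon and the rest of the structure stays the same.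

Going by the values given here, the only measured step at that place is a 44-fold lower number from compound 1 to compound 2 (1.64 log units; beyond the scatter) when naphthalen-2-yl enters in place of 4-(trifluoromethoxy)phenyl. That step is large, so a rise in the number is expected now that naphthalen-2-yl leaves. As far as these compounds go, its size is uncertain, since a single step shows no trend and 3-fluorophenyl itself is untested. The expected change is a 12-fold higher number from compound 2 to compound 3 (1.08 log units; beyond the scatter) and it should stay beyond the scatter. For compound 3 the estimated value is 60 nM with 12 nM to 300 nM as its expected range.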

Compound 3, half-maximal inhibitory concentration: 590 nM
For compound 3 the middle estimate is 9.8-fold (0.99 log units) below the measured one; measured number above the stated range.
By their numbers in this assay, from the lowest: compound 2; then compound 1; then compound 3.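

In this assay the change from naphthalen-2-yl to 3-fluorophenyl on a double-bonded chain carbon bound to a double-bonded chain carbon gives a 120-fold higher number from compound 2 to compound 3 (2.07 log units; beyond the scatter) and so costs more than the earlier pair alone had shown. The other single-ring comparison gives a 2.7-fold higher number from compound 1 to compound 3 (0.43 log units; beyond the scatter) and makes compound 3 the weakest of the three, so at this place the two-ring naphthalen-2-yl stands apart from both one-ring groups, while the choice of group on the single ring also moves the number, though far less. Nothing available here accounts for either step or says what sets the two-ring group apart from the one-ring groups.

Going by these compounds alone, with only three compounds, the ring count and the group on the ring cannot be separated, since compound 2 carries no group on its rings and compound 1 and compound 3 differ in both the group and where it sits. Plain phenyl would give the missing reference point, and an amine or a carboxylic acid on that ring would show how far this place tolerates groups of a different kind.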